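From formyl to methyl on a shared core

The source may hold more compounds than are shown below. What is called first, only, known or untested is meant among the compounds shown, and "the series" means these compounds.

Compound 1 `CC1(C)C(CC[C@@H]2[C@@]3(C)CC[C@@H](O)C(C)(C)O[C@@H]3CC[C@]2(C)O)C(C=O)=CCC2C1CC[C@@]2(C)O`: 5 nM
Compound 2 `CC1(C)O[C@@H]2CC[C@](C)(O)[C@H](CCC3C(CO)=CCC4C(CC[C@@]4(C)O)C3(C)C)[C@@]2(C)CCC1=O`: 6.3 nM

Both numbers come from a functional assay on KB 3-1 cells (Homo sapiens) for cytotoxicity, read by MTT assay, with a stated time of 68 h, tested at 5 uM; on this read-out lower numbers stand for stronger inhibition and higher numbers for weaker inhibition. In this assay compound 1 gives 5 nM and compound 2 gives 6.3 nM. These two values lie within the scatter of each other, and compound 1 stands level with compound 2 on the numbers available.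

Compound 3 `CC1=CCC2C(CC[C@@]2(C)O)C(C)(C)C1CC[C@@H]1[C@@]2(C)CC[C@@H](O)C(C)(C)O[C@@H]2CC[C@]1(C)O` has not yet been measured in this assay. It departs from compound 1 in one place: methyl in place of formyl on a double-bonded ring carbon. This is methyl in place of formyl on a double-bonded ring carbon, next to the ring atom that bears a large group.

Among the compounds with values here, no measured step in this small set shows what such a replacement does, and the forecast is weakly founded. The expectation starts from compound 1 at 5 nM and allows a modest move toward a higher number, one that may stay within the scatter. The expected change is a 1.6-fold higher number from compound 1 to compound 3 (0.20 log units; within the scatter). For compound 3 the estimated value is 8 nM, with an expected range from 2.5 nM to 30 nM.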

Compound 3, half-maximal inhibitory concentration: 5 nM
Estimate against measurement, compound 3: 1.6-fold (0.20 log units) above; the range from low to high includes it.
By their numbers in this assay, from the lowest: compounds 1, 3 and 2 (each within the scatter of the next).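

In this assay, replacing formyl with methyl on a double-bonded ring carbon, next to the ring atom that bears a large group, gives no change at the digits printed from compound 1 to compound 3 (within the scatter). Within the data shown here, this is the first measured step at this position, and it shows that the formyl group, with its carbonyl and its hydrogen-bond acceptor, can give way to methyl, a group with one heavy atom and no hydrogen-bond acceptor, without a change in the read-out on the shared core. Nothing available explains this lack of change, and the result alone does not establish a cause.

The compounds shown leave open whether this position would accept a group that differs more strongly from both formyl and methyl, such as an amine, a carboxylic acid or a longer chain, or whether the read-out would then move beyond the scatter. Among these compounds, they also leave open whether the same replacement would behave alike on a core changed elsewhere, as this one pair is the only direct comparison at this position.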